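Replacing a ring with an open chain at the amide of compound 3

The source may hold more compounds than are shown below. What is called first, only, known or untested is meant among the compounds shown, and "the series" means these compounds.

Of the compounds shown here, three sharing one core have been measured. Compound 1 `CC(C)(C)c1ccc(C(=O)N2CCC3(CC2)C(=O)N(CC(=O)N2CCN(S(C)(=O)=O)CC2)CN3c2ccccc2)cc1` gives 19000 nM in an assay on HEK293 cells for displacement of a labelled ligand from NPC1-like intracellular cholesterol transporter 1 (Homo sapiens); on this read-out higher numbers stand for weaker inhibition and lower numbers for stronger inhibition. Compound 2 `CC(C)(C)c1ccc(C(=O)N2CCC3(CC2)C(=O)N(CC(=O)N2CCCC(CO)C2)CN3c2ccccc2)cc1` gives 8200 nM, and compound 3 `CCOC(=O)C1CCN(C(=O)CN2CN(c3ccccc3)C3(CCN(C(=O)c4ccc(C(C)(C)C)cc4)CC3)C2=O)CC1` gives 3100 nM, the lowest of the three numbers and so the strongest inhibitor found so far. The three differ only in the group attached to one carbonyl carbon, and every swap there moved the number: a 2.3-fold lower number from compound 1 to compound 2 (0.36 log units; beyond the scatter), a 6.1-fold lower number from compound 1 to compound 3 (0.79 log units; beyond the scatter) and a 2.6-fold lower number from compound 2 to compound 3 (0.42 log units; beyond the scatter). Compound 4 `CC(C)(C)c1ccc(C(=O)N2CCC3(CC2)C(=O)N(CC(=O)NCCCNS(C)(=O)=O)CN3c2ccccc2)cc1` changes that same carbonyl carbon again: (3-(methanesulfonamido)propyl)amino in place of 4-(ethoxycarbonyl)piperidin-1-yl on a carbonyl carbon. This is a bigger structural change than any between compounds 1, 2 and 3, since a ring is exchanged for an open chain. Among the measured compounds shown here, the one measured compound that carries a methylsulfonyl group, compound 1, gives the highest number, and its step to compound 3 was the largest seen. Weaker inhibition is therefore expected for compound 4, a step of about a 4.8-fold higher number from compound 3 to compound 4 (0.68 log units; beyond the scatter). Compound 4 is estimated at 15000 nM, with a range from 4000 nM to 60000 nM.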

Compound 4, half-maximal inhibitory concentration: 10400 nM
The estimate for compound 4 lay 1.4-fold (0.16 log units) above the measured number; low and high end bracket the measured number.
By their numbers in this assay, from the lowest: compound 3; then compounds 2, 4 and 1 (each within the scatter of the next, the first and the last beyond it).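

In this assay, this position still accepts an open chain in place of a ring, at a cost of a 3.4-fold higher number from compound 3 to compound 4 (0.53 log units; beyond the scatter). Against the other two rings the chain shows no separation, with a 1.3-fold higher number from compound 2 to compound 4 (0.10 log units; within the scatter) and a 1.8-fold lower number from compound 1 to compound 4 (0.26 log units; within the scatter), so having a ring on this carbonyl carbon does not by itself set the number, and of the three rings only 4-(ethoxycarbonyl)piperidin-1-yl stands clear of the chain. No measurement at hand explains why these groups differ.

The compounds shown do not separate the chain from its methanesulfonamido end, since both differ from the ring at once. A plain propyl chain, or a propyl chain ending in an ethyl ester or a carboxylic acid, would show which of the two parts counts.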